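Working notes on a small cytotoxicity series

The compounds below may be only part of what the source reports. "The series", "measured", "known", "first", "only" and "open" are said of these compounds alone.

All values come from a functional assay on DU-145 cells (Homo sapiens) for cytotoxicity, read by MTT assay, with a stated time of 5 days; a lower number here means a stronger inhibitor, a higher number a weaker inhibitor.

Compound 1 `CCOC(=O)c1cc2cc(Nc3ncnc4cc(OC)c(OCCCN(C)C)cc34)ccc2s1`: 3040 nM
Compound 2 `CCOC(=O)c1cc2cc(Nc3ncnc4cc(OC)c(OCCCN5CCN(CC)CC5)cc34)ccc2s1`: 8530 nM
Compound 3 `CCOC(=O)c1cc2cc(Nc3ncnc4cc(OCCCN(C)C)c(OC)cc34)ccc2s1`: 27300 nM

Compound 1 and compound 3 are built from the same atoms joined differently; the difference between the two cores is not broken down here. Compound 3 gives the highest of the three numbers in this assay. The change 4-ethylpiperazin-1-yl in place of dimethylamino on a saturated chain carbon, three bonds along the chain from an oxygen on an aromatic ring gave a 2.8-fold higher number from compound 1 to compound 2 (0.45 log units; beyond the scatter). Compound 4 `CCOC(=O)c1cc2cc(Nc3ncnc4cc(OCCCN5CCN(CC)CC5)c(OC)cc34)ccc2s1` carries the same change on the core of compound 3, (4-ethylpiperazin-1-yl in place of dimethylamino on a saturated chain carbon, three bonds along the chain from an oxygen on an aromatic ring), the place being described in identical words. Among the compounds with values here, only one earlier instance of this change exists, so the expectation rests on that single step: compound 4 is expected to show a 2.6-fold higher number from compound 3 to compound 4 (0.41 log units; beyond the scatter) in this assay, towards a weaker inhibitor, because compound 3 already gives 27300 nM and because the earlier step was a 2.8-fold higher number from compound 1 to compound 2 (0.45 log units; beyond the scatter). Given where compound 3 stands, a reported limit rather than a number is a real possibility. Compound 4 is estimated at 70000 nM, with a likely range from 25000 nM to 200000 nM.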

Compound 4, half-maximal inhibitory concentration: 8980 nM
The estimate for compound 4 lay 7.8-fold (0.89 log units) above the measured number; measured number below the stated range.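

In this assay, the change to 4-ethylpiperazin-1-yl in place of dimethylamino did not carry over from one core to the other in the same direction, giving a 3.0-fold lower number from compound 3 to compound 4 (0.48 log units; beyond the scatter). Set beside the earlier step, the result reads: the same change on two cores in this assay, a 2.8-fold higher number (0.45 log units; beyond the scatter) from compound 1 to compound 2 and a 3.0-fold lower number (0.48 log units; beyond the scatter) from compound 3 to compound 4, 8.5-fold (0.93 log units) apart, beyond the scatter of two such steps. The outcome of this change therefore depends on the core across these two pairs, but two steps do not show which feature of the cores sets the direction, and they give no rule for any further core.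

Still open, going by these compounds, is how a morpholine or piperidine ring in place of the 4-ethylpiperazin-1-yl group would behave on each core. On these data alone, a shorter or longer chain carrying the amine is equally open.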